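Azetidine to Pyrrolidine Carboxamide in a Weak Series

The source may hold more compounds than are shown below. What is called first, only, known or untested is meant among the compounds shown, and "the series" means these compounds.

Compound 1 `NC(=O)C1CCN1Cc1ccc(OCc2cccc(F)c2)cc1` gives 18000 nM in an assay on Sf9 cells for inhibition of Amine oxidase [flavin-containing] A (Homo sapiens), with stated times of 15 min and 60 min (a lower number here means a stronger inhibitor, a higher number a weaker inhibitor), and compound 2 `CC1(C)C[C@@H](C(N)=O)N(Cc2ccc(OCc3cccc(F)c3)cc2)C1` gives 17500 nM in this assay. Compound 3 `NC(=O)C1CN(Cc2ccc(OCc3cccc(F)c3)cc2)C1` reaches only a limit of the assay, > 10000 nM, in this assay. The step that the limit leaves unreadable from compound 1 to compound 3 is therefore unreadable, because the limit of > 10000 nM in this assay, at which 1 of the 3 values shown sits, marks where compound 3 sits. Compound 4 `NC(=O)[C@@H]1CCCN1Cc1ccc(OCc2cccc(F)c2)cc1` differs from compound 3 by 2-carbamoylpyrrolidin-1-yl in place of 3-carbamoylazetidin-1-yl on a saturated chain carbon bound to an aromatic carbon. Going by the values given here, no measured step covers this exchange, so the expectation rests on compound 1 and compound 2, whose values lie within the scatter of each other. Compound 4 is estimated at 15000 nM, with a range from 5000 nM to 40000 nM. The implied step that the limit leaves unreadable from compound 3 to compound 4 is an estimate only, as it starts from a limit.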

Compound 4, half-maximal inhibitory concentration: 34200 nM
Compound 4: the middle estimate sits 2.3-fold (0.36 log units) below what was measured; measured number inside the range.
By their numbers in this assay, from the lowest: compounds 2, 1 and 4 (each within the scatter of the next).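

The exchange of 2-carbamoylazetidin-1-yl for 2-carbamoylpyrrolidin-1-yl on a saturated chain carbon bound to an aromatic carbon gives a 1.9-fold higher number from compound 1 to compound 4 (0.28 log units; within the scatter) in this assay, so the five-membered ring brings no readable change over the four-membered one. The step from compound 3 to compound 4 cannot be read, because compound 3 stands only at a limit of the assay: the limit of > 10000 nM in this assay, at which 1 of the 4 values shown sits.

The compounds shown leave open whether a carboxylic acid or an amine in place of the carboxamide on this ring would move the number beyond the scatter.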